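Chloro on the benzothiazole of compound 3: expected step

The source may hold more compounds than are shown below. What is called first, only, known or untested is meant among the compounds shown, and "the series" means these compounds.

In a functional assay on A549 cells (Homo sapiens) for antiproliferative activity, read by MTT assay, with a stated time of 48 h (on this read-out higher numbers stand for weaker inhibition and lower numbers for stronger inhibition), compound 3 (`Oc1ccc2ccccc2c1C(Nc1nc2ccccc2s1)c1cn(-c2ccccc2)nc1-c1ccc(I)cc1`) gives 23100 nM, level with compound 1 (`COc1ccc(-c2nn(-c3ccccc3)cc2C(Nc2nc3ccccc3s2)c2c(O)ccc3ccccc23)cc1`) at 26200 nM. Compound 2 (`Cc1ccc(-c2nn(-c3ccccc3)cc2C(Nc2nc3ccccc3s2)c2c(O)ccc3ccccc23)cc1`) gives 57400 nM, and the gap to compound 3 is a 2.5-fold lower number from compound 2 to compound 3 (0.40 log units; beyond the scatter).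

Compound 4 (`Oc1ccc2ccccc2c1C(Nc1nc2ccc(Cl)cc2s1)c1cn(-c2ccccc2)nc1-c1ccc(I)cc1`) has chloro in place of hydrogen on an aromatic carbon, turning 1,3-benzothiazol-2-yl into 6-chloro-1,3-benzothiazol-2-yl: chloro in place of hydrogen on an aromatic carbon.

Among the measured compounds shown here, no measured step changes this position, so the evidence is indirect. The three measured steps all exchange one aromatic substituent for another elsewhere in the molecule. They are a 2.2-fold higher number from compound 1 to compound 2 (0.34 log units; beyond the scatter), a 1.1-fold lower number from compound 1 to compound 3 (0.05 log units; within the scatter) and a 2.5-fold lower number from compound 2 to compound 3 (0.40 log units; beyond the scatter), so the largest are modest and one lies within the scatter. They give no direction for the new chloro group. In this assay, no step beyond the scatter is therefore expected, although a modest move either way remains possible. The expected step is a 1.2-fold lower number from compound 3 to compound 4 (0.06 log units; within the scatter). The estimate for compound 4 is 20000 nM, with an expected range of 9000 nM to 45000 nM.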

Compound 4, half-maximal inhibitory concentration: 29000 nM
Compound 4: the middle estimate sits 1.5-fold (0.16 log units) below what was measured, within the range that was stated.
By their numbers in this assay, from the lowest: compounds 3, 1, 4 and 2 (each within the scatter of the next, the first and the last beyond it).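

Among the compounds shown here, the step of a 1.3-fold higher number from compound 3 to compound 4 (0.10 log units; within the scatter) in this assay is the first reading at this position. It shows that chloro can stand on this aromatic carbon, turning 1,3-benzothiazol-2-yl into 6-chloro-1,3-benzothiazol-2-yl, without a change beyond the scatter, so this position is so far as silent as the exchange of iodo for methoxy elsewhere in the molecule. No measurement of any property of these compounds is available to interpret this step.

As far as these compounds go, one substituent gives no trend at this position, so whether an amine or a carboxylic acid in place of chloro would move the number either way remains open. Also open, from the compounds shown here alone, is whether chloro here behaves the same with methoxy or methyl in place of iodo, as in compound 1 and compound 2.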